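Nitro for trifluoromethyl on a shared ring-opening core

A few compounds are considered here, and "the series" means these few. Any claim that something is new, unique, unknown or untested is made for them only; others in the source may bear on it.

Measured compounds and their values:
compound 1, `Cc1ncccc1OC[C@@H]1CCCN1C`, 22.9 nM
compound 2, `Cc1ccncc1OC[C@@H]1CCCN1C`, 4.12 nM
compound 3, `CN1CCC[C@H]1COc1cncc(C(F)(F)F)c1`, 1.83 nM

All three were tested in an assay on membranes from brain for displacement of a labelled ligand from Neuronal acetylcholine receptor; alpha4/beta2 (Rattus norvegicus); on this read-out lower numbers stand for stronger inhibition and higher numbers for weaker inhibition. Compound 3 gives the lowest of the three numbers, and so the strongest binding, in this assay. Its nearest neighbour is compound 2, whose number is higher by an amount beyond the usual scatter, and the furthest is compound 1, whose number is higher still. Compound 3 therefore stands clearly ahead of the other two measured compounds.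

Compound 4, `CN1CCC[C@H]1COc1cncc([N+](=O)[O-])c1`, has not yet been measured. It differs from compound 3 in one place: nitro in place of trifluoromethyl on an aromatic carbon. The change keeps the rest of the molecule unchanged and exchanges one small group for another of similar size on the same aromatic carbon.

Going by the values given here, no pair of measured compounds shows this exchange, so there is no step from which its size can be read. Without such a step, the plain expectation is that compound 4 stays close to compound 3, with any step from compound 3 to compound 4 expected to lie within the scatter, as a 1.1-fold lower number from compound 3 to compound 4 (0.06 log units; within the scatter). Compound 4 is thus estimated at 1.6 nM in this assay, most likely between 0.5 nM and 5 nM.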

Compound 4, inhibition constant: 4.65 nM
Compound 4: middle estimate off by 2.9-fold (0.46 log units), on the low side; low and high end bracket the measured number.
By their numbers in this assay, from the lowest: compound 3; then compounds 2 and 4 (each within the scatter of the next); then compound 1.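

In this assay, the exchange of trifluoromethyl for nitro on this aromatic carbon turns out not to be neutral: the measured change is a 2.5-fold higher number from compound 3 to compound 4 (0.41 log units; beyond the scatter) and, though modest, it shows that this position responds to which of the two groups it carries. The earlier compounds shown here could not show this, since none of them offered a pair differing in one place. The two groups differ in what can be counted, with trifluoromethyl having 4 heavy atoms and 0 hydrogen-bond acceptors and nitro having 3 heavy atoms and 2 hydrogen-bond acceptors, but no measurement here connects either difference to the change in binding, so the reason for the step remains unknown.

The compounds shown leave open how other groups on this same aromatic carbon would fare, such as a nitrile, an amine, a carboxylic acid or a longer chain, and so how wide a range of groups this position accepts. They also leave open whether nitro in place of trifluoromethyl would give a step of similar size on a different core.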